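The compounds below may be only part of what the source reports. "The series", "measured", "known", "first", "only" and "open" are said of these compounds alone.

Of the compounds shown here, three have been measured in a functional assay on MCF7 cells (Homo sapiens) for antiproliferative activity, read by sulforhodamine B assay, with a stated time of 48 h, tested at 50 uM; a higher number here means more inhibition at the concentration tested (going by the name of the read-out), a lower number less inhibition. Compound 1 `CC1=CC[C@H](C(C)C)c2cc(C)c(OC(=O)c3ccc(C)cc3)cc21` gives 65%. Compound 2 `CC1=CC[C@H](C(C)C)c2cc(C)c(OC(=O)Nc3ccccc3)cc21` gives 75.1%. Compound 3 `CC1=CC[C@H](C(C)C)c2cc(C)c(OC(=O)c3ccc(Cl)cc3)cc21` gives 79.7%.

Compound 3 holds the highest of the three numbers, though the gap a number 4.6 percentage points higher from compound 2 to compound 3 (within the scatter) is within the scatter, while a number 14.7 percentage points higher from compound 1 to compound 3 (beyond the scatter) lies beyond it. Compound 4 `CC1=CC[C@H](C(C)C)c2cc(C)c(OC(=O)c3cccc(Cl)c3)cc21` differs from compound 3 only in this way: 3-chlorophenyl in place of 4-chlorophenyl on a carbonyl carbon. Among the compounds with values here, no measured step moves the chloro around the ring; the only step touching that ring, a number 14.7 percentage points higher from compound 1 to compound 3 (beyond the scatter), swaps chloro for methyl. Nothing in the data therefore points to a step beyond the scatter in this assay. Compound 4 is expected to give 75%, between 60% and 88%, a step of a number 4.7 percentage points lower from compound 3 to compound 4 (within the scatter) estimated against compound 3.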

Compound 4, a percentage reported as inhibition, at one concentration (the size of the read-out at that concentration, not a potency): 40.4%
Estimate against measurement, compound 4: 34.6 percentage points above, outside the stated range (below it).
By their numbers in this assay, from the lowest: compound 4; then compound 1; then compounds 2 and 3 (each within the scatter of the next).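

In this assay, the chloro's place on the ring matters: 3-chlorophenyl in place of 4-chlorophenyl on a carbonyl carbon gives a number 39.3 percentage points lower from compound 3 to compound 4 (beyond the scatter), a large step between two compounds with the same atoms. Compound 4 also stands apart from the other two compounds, with a number 34.7 percentage points lower from compound 2 to compound 4 (beyond the scatter) and a number 24.6 percentage points lower from compound 1 to compound 4 (beyond the scatter), so among these four, having a chloro on this ring does not by itself give a high number. Nothing measured here accounts for the step.

From the compounds shown here alone, it remains open whether a bromo or a methoxy group in place of the chloro of 3-chlorophenyl would give a step of this size. Going by these compounds, it is also open whether a chloro on the anilino ring of compound 2 would shift the number in the same way.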